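The source may report more compounds than this note shows. Statements on the series, on what has been measured and on what is new or still open speak of the compounds shown alone.

Of the compounds shown here, two sharing one core have so far been measured in a functional assay on BXPC-3 cells (Homo sapiens) for cytotoxicity, read by MTT assay, with a stated time of 72 h; a higher number here means a weaker inhibitor, a lower number a stronger inhibitor. Compound 1 `CC(C)(C)c1[nH]cnc1/C=c1\[nH]c(=O)/c(=C/c2cccc(Oc3ccc(F)cc3)c2)[nH]c1=O` gives 3.2 nM, and compound 2 `CC(C)c1[nH]cnc1/C=c1\[nH]c(=O)/c(=C/c2cccc(Oc3ccc(F)cc3)c2)[nH]c1=O` gives 3.4 nM. Between them lies a 1.1-fold higher number from compound 1 to compound 2 (0.03 log units; within the scatter), so compound 2 stands level with compound 1 and neither can be ranked over the other.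

Compound 3 `O=c1[nH]/c(=C\c2nc[nH]c2C2CC2)c(=O)[nH]/c1=C\c1cccc(Oc2ccc(F)cc2)c1` differs from compound 2 in one place: cyclopropyl in place of isopropyl on an aromatic carbon. In words, cyclopropyl stands in place of isopropyl on an aromatic carbon, turning 5-isopropyl-1H-imidazol-4-yl into 5-cyclopropyl-1H-imidazol-4-yl.

Within the data shown here, only one measured step bears on this change, since it alters the same group: hydrogen in place of methyl on the chain carbon bound to the aromatic carbon, which gave a 1.1-fold higher number from compound 1 to compound 2 (0.03 log units; within the scatter). Among the measured compounds shown here, that is thin evidence, and no measured compound carries a ring at this place. The expectation in this assay is therefore no step beyond the scatter and no firm direction, held with a fairly wide range. The estimated step is a 1.2-fold higher number from compound 2 to compound 3 (0.07 log units; within the scatter). For compound 3 the expected value is 4 nM, with an estimated range of 1.5 nM to 12 nM.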

Compound 3, half-maximal inhibitory concentration: 9.4 nM
Beside the measured number, compound 3's estimate is 2.4-fold (0.37 log units) below it, within the range that was stated.
By their numbers in this assay, from the lowest: compounds 1 and 2 (each within the scatter of the next); then compound 3.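

Replacing isopropyl with cyclopropyl gives a 2.8-fold higher number from compound 2 to compound 3 (0.44 log units; beyond the scatter) in this assay, and replacing tert-butyl with cyclopropyl gives a 2.9-fold higher number from compound 1 to compound 3 (0.47 log units; beyond the scatter) (both modest), so this carbon of the five-membered aromatic ring is not indifferent to the group it carries, as the first pair alone might have suggested. Isopropyl and cyclopropyl have the same count of 3 heavy atoms, all carbon, and neither has a hydrogen-bond donor or acceptor, so the clearest counted difference in this swap is the three-membered ring, and this is the first step in the series to pass beyond the scatter, towards weaker inhibition. Nothing available here offers a measured explanation for this loss.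

The compounds shown leave open whether the weaker result belongs to cyclopropyl alone or to rings at this place more generally, which a cyclobutyl or cyclopentyl group could test, and how a smaller methyl or a group holding nitrogen, such as an amine, would read. They also cannot tell whether the step would keep its size if the fluorine elsewhere in the molecule were replaced by hydrogen.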